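Naphthyl for methoxyphenyl on the saturated ring carbon

This account rests on a few compounds, and the source may have more. Where it says the series, first, only, none or still open, it means among the compounds named here.

Of the compounds shown here, three of a shared core have been measured in a functional assay on Ehrlich cells (Mus musculus) for antiproliferative activity, read by trypan blue exclusion, with a stated time of 2 h, tested at 10 ug/mL; a lower number here means a weaker effect, a higher number a stronger effect of the compound at the concentration tested. Compound 1 `Cc1ccc(C2C(C#N)=C(N)N(c3ccc(S(N)(=O)=O)cc3)C3=C2C(=O)CCC3)cc1` gives 30%, compound 2 `COc1ccccc1C1C(C#N)=C(N)N(c2ccc(S(N)(=O)=O)cc2)C2=C1C(=O)CCC2` gives 0%, and compound 3 `COc1ccc(C2C(C#N)=C(N)N(c3ccc(S(N)(=O)=O)cc3)C3=C2C(=O)CCC3)cc1` gives 30%. Compound 3 thus stands level with compound 1 at the digits printed, the two together the highest of the three numbers, while compound 2 lies a number 30 percentage points higher from compound 2 to compound 3 (beyond the scatter) below it. The known steps are no change at the digits printed from compound 1 to compound 3 (within the scatter), a swap of methoxy for methyl on an aromatic carbon, and a number 30 percentage points lower from compound 1 to compound 2 (beyond the scatter) together with a number 30 percentage points higher from compound 2 to compound 3 (beyond the scatter), which show that moving the methoxy group on the aryl ring attached to the saturated ring carbon shifts the read-out beyond the scatter.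

Compound 4 `COc1ccc(C2C(C#N)=C(N)N(c3ccc(S(N)(=O)=O)cc3)C3=C2C(=O)CCC3)c2ccccc12` differs from compound 3 by 4-methoxynaphthalen-1-yl in place of 4-methoxyphenyl on a saturated ring carbon. Among the compounds with values here, no measured step extends the aryl group to a second fused aromatic ring, so the bearing of the known steps is indirect: they only show that this position tolerates a 4-methoxyphenyl and a 4-methylphenyl alike and is sensitive to how the group is arranged. He therefore expects a step of a number 5 percentage points lower from compound 3 to compound 4 (within the scatter) in this assay, likely within or close to the scatter, and estimates compound 4 at 25%, between 5% and 50%.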

Compound 4, a percentage reported as activity, at one concentration (the size of the read-out at that concentration, not a potency): 10%
For compound 4 the middle estimate is 15 percentage points above the measured one; low and high end bracket the measured number.
By their numbers in this assay, from the lowest: compounds 2 and 4 (each within the scatter of the next); then compounds 1 and 3 (each within the scatter of the next).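

In this assay, the position on the saturated ring carbon proves less forgiving than the swap between 4-methylphenyl and 4-methoxyphenyl suggested: extending the aryl group to 4-methoxynaphthalen-1-yl gives a number 20 percentage points lower from compound 3 to compound 4 (beyond the scatter) and, measured against the methyl compound, a number 20 percentage points lower from compound 1 to compound 4 (beyond the scatter) at the one concentration tested. The new group also lands with the 2-methoxyphenyl group, with a number 10 percentage points higher from compound 2 to compound 4 (within the scatter), so two different departures from the 4-methoxyphenyl group, the shifted methoxy and the second fused aromatic ring, both leave the read-out at the low level among the measured compounds. Nothing in hand bears on why this change lowers the read-out.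

From the compounds shown here alone, it remains open whether the drop belongs to the second fused ring alone or to that ring together with its methoxy, a question that a plain naphthalen-1-yl group on this carbon would address. Equally open, going by these compounds, is how this carbon would respond to an aryl group carrying an amine or a carboxylic acid in place of the methoxy, or to a longer alkoxy chain.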